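Aryl carbonyl variation on a shared core

The source may report more compounds than this note shows. Statements on the series, on what has been measured and on what is new or still open speak of the compounds shown alone.

Measured so far:
compound 1, `CC1(C)S[C@@H]2/C(=C\C(=O)c3ccc4ccccc4c3)C(=O)N2[C@H]1C(=O)OC(c1ccccc1)c1ccccc1`: in a functional assay on A-375 cells (Homo sapiens) for cytotoxicity, read by MTT assay, with a stated time of 48 h (on this read-out lower numbers stand for stronger inhibition and higher numbers for weaker inhibition), compound 1 gives 36500 nM.
compound 2, `CC1(C)S[C@@H]2/C(=C\C(=O)c3ccco3)C(=O)N2[C@H]1C(=O)OC(c1ccccc1)c1ccccc1`: in this assay compound 2 gives 26000 nM.

Among the compounds with values here, compound 2 holds the lowest of the two numbers, but its only neighbour is compound 1, and the step of a 1.4-fold lower number from compound 1 to compound 2 (0.15 log units; within the scatter) lies within the scatter, so no order between the two can be read. Within the data shown here, the single step on record, naphthalen-2-yl to furan-2-yl on a carbonyl carbon, shows that exchanging the aryl group at this position left the read-out essentially unchanged.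

Compound 3, `CC1(C)S[C@@H]2/C(=C\C(=O)c3ccc(C(F)(F)F)cc3)C(=O)N2[C@H]1C(=O)OC(c1ccccc1)c1ccccc1`, is the next member. Its change from compound 2: 4-(trifluoromethyl)phenyl in place of furan-2-yl on a carbonyl carbon. Among the measured compounds shown here, the same carbonyl carbon is varied as in the step from compound 1 to compound 2, and that step was flat; no measured step brings a six-membered aromatic ring of carbon only, or a trifluoromethyl group, into this position, so nothing beyond the scatter can be predicted. In this assay the step of a 1.2-fold higher number from compound 2 to compound 3 (0.06 log units; within the scatter) is expected to stay inside the scatter. The estimate for compound 3 in this assay is 30000 nM, ranging from 12000 nM to 75000 nM.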

Compound 3, half-maximal inhibitory concentration: 26700 nM
Estimate against measurement, compound 3: 1.1-fold (0.05 log units) above; the measured number falls inside the stated range.
By their numbers in this assay, from the lowest: compounds 2, 3 and 1 (each within the scatter of the next).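

Within the data shown here, with compound 3, a six-membered aromatic ring of carbon only, carrying a trifluoromethyl group, stands on the carbonyl carbon for the first time, and in this assay neither the step of a 1.0-fold higher number from compound 2 to compound 3 (0.01 log units; within the scatter) nor the step of a 1.4-fold lower number from compound 1 to compound 3 (0.14 log units; within the scatter) leaves the scatter. Among these compounds, the earlier pair covered only naphthalen-2-yl and furan-2-yl, whereas three different aryl groups on this carbonyl carbon now give numbers that cannot be told apart, and no compound among them is set apart from the other two. Nothing on record offers a reason for this flat result.

Open, going by these compounds, is whether any group on this carbonyl carbon can move the number beyond the scatter, for example a phenyl ring bearing an amine or a carboxylic acid, or a longer alkyl chain in place of the aryl ring. Among the compounds shown here, also open is whether changes elsewhere on the shared core would do so, as every step so far sits at this one carbonyl carbon.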